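Removing the Boc group and widening the saturated ring

The source may hold more compounds than are shown below. What is called first, only, known or untested is meant among the compounds shown, and "the series" means these compounds.

Measured compounds:
Compound 1 `CC(C)(C)OC(=O)N1CCC[C@H]1C(=O)N1CCC(NS(=O)(=O)c2cc(S(=O)(=O)c3ccccc3)ccc2C(F)(F)F)CC1` gives 60 nM in an assay on U2OS cells for inhibition of secreted frizzled-related protein 1 (Homo sapiens), read by a luciferase reporter, with a stated time of 18 h; a higher number here means that more compound is needed for the effect, a lower number that less compound is needed.
Compound 2 `CC(C)(C)OC(=O)N1CC[C@@H](C(=O)N2CCC(NS(=O)(=O)c3cc(S(=O)(=O)c4ccccc4)ccc3C(F)(F)F)CC2)C1` gives 80 nM in this assay.

Going by the values given here, compound 2 stands at the highest of the two numbers, and its only neighbour is compound 1; the single measured step, a 1.3-fold higher number from compound 1 to compound 2 (0.12 log units; within the scatter), lies within the scatter, so the two compounds are not distinguished. Compound 3 `O=C(C1CCNCC1)N1CCC(NS(=O)(=O)c2cc(S(=O)(=O)c3ccccc3)ccc2C(F)(F)F)CC1` differs from compound 2 by piperidin-4-yl in place of 1-(tert-butoxycarbonyl)pyrrolidin-3-yl on a carbonyl carbon. Among the compounds with values here, no measured step covers this change: the one step available concerns only the attachment point on the five-membered ring and does not touch the tert-butoxycarbonyl group or the free ring nitrogen that now enters. The expectation for this assay therefore rests on little, and the step of a 1.9-fold higher number from compound 2 to compound 3 (0.27 log units; within the scatter) is estimated as modest, leaning toward a higher number, with wide uncertainty. Compound 3 is estimated at 150 nM, between 40 nM and 600 nM.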

Compound 3, half-maximal effective concentration: 150 nM
Compound 3: middle estimate and measured number agree at the digits printed, and the stated range covers the measured number.
By their numbers in this assay, from the lowest: compounds 1, 2 and 3 (each within the scatter of the next, the first and the last beyond it).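

Placing piperidin-4-yl on the carbonyl carbon in place of 1-(tert-butoxycarbonyl)pyrrolidin-3-yl gives a 1.9-fold higher number from compound 2 to compound 3 (0.27 log units; within the scatter), so this assay does not tell this pair apart, although the entering group has no tert-butoxycarbonyl group and carries a hydrogen-bond donor. Measured against 1-(tert-butoxycarbonyl)pyrrolidin-2-yl, the same group gives a 2.5-fold higher number from compound 1 to compound 3 (0.40 log units; beyond the scatter), a modest step and the only one so far that passes the scatter. No measurement at hand explains either step.

The compounds shown leave open how much of that step belongs to the missing tert-butoxycarbonyl group and how much to the six-membered ring, as the two change together. They also leave open how an acetyl or methyl group on the nitrogen of the piperidin-4-yl group would read.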